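One change on the amide-type nitrogen of a shared core

The source may hold more compounds than are shown below. What is called first, only, known or untested is meant among the compounds shown, and "the series" means these compounds.

The shared core appears in compound 1 `COc1cc2c(cc1OC)C(=O)C(CC1CCN(C(=S)Nc3cccc(C)c3)CC1)C2`, compound 2 `COc1cc2c(cc1OC)C(=O)C(CC1CCN(C(=S)Nc3ccc(C)cc3)CC1)C2` and compound 3 `COc1cc2c(cc1OC)C(=O)C(CC1CCN(C(=S)Nc3cccc([N+](=O)[O-])c3)CC1)C2`, which differ only in the group carried on an amide-type nitrogen. Of the three, only compound 2 has a number: in a functional assay on the whole organism (strain Swiss albino) with Mus musculus as the target, with a stated time of 4 h (a lower number here means that less compound is needed, a higher number that more compound is needed for the effect), compound 2 gives 300 mg/kg. In this assay compound 1 gives "not determined" (no result reported). In this assay compound 3 gives "not determined" (no result reported). For compound 1 and compound 3 no result was reported, so compound 2 stands alone as the single reference point. The next compound, compound 4 `COc1cc2c(cc1OC)C(=O)C(CC1CCN(C(=S)Nc3ccccc3Cl)CC1)C2`, keeps the core and alters that one group: 2-chlorophenyl in place of 4-methylphenyl on an amide-type nitrogen. Among the compounds with values here, no measured pair in this set differs in a single place, so there is no measured step to lean on. With only the value of compound 2 to go by, the expected step of no change at the digits printed from compound 2 to compound 4 (within the scatter) has no clear direction, and its size is expected to stay close to the usual scatter, though the uncertainty is wide. Compound 4 is therefore estimated at 300 mg/kg in this assay, with a likely range from 100 mg/kg to 1000 mg/kg.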

Compound 4, minimum effective dose: 300 mg/kg
Compound 4: the middle estimate sits on the measured number at the digits printed, within the range that was stated.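

In this assay, within the data shown here, the replacement of 4-methylphenyl by 2-chlorophenyl on an amide-type nitrogen gives no change at the digits printed from compound 2 to compound 4 (within the scatter) and so provides the only readable step in this set. This shows that, at this position, the whole organism response can stay the same when one seven-heavy-atom aromatic group replaces another, even though both the added atom and its place on the ring differ. No supporting measurement is available to explain why these two groups read alike.

Because the two changes arrive together, the effect of chlorine and the effect of its place on the ring cannot be separated, and steps involving compound 1 and compound 3 cannot be read. On these data alone, it also remains open how this assay would respond to a carboxylic acid, an amine or a longer chain on that nitrogen.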